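This account rests on a few compounds, and the source may have more. Where it says the series, first, only, none or still open, it means among the compounds named here.

Compound 1 `COC(=O)c1ccc(N2CCC(O)(Cn3cnc4c(Br)n(C)nc4c3=O)CC2)c(Cl)c1` is one of two compounds here with a number: in an assay on Sf21 cells for inhibition of ubiquitin carboxyl-terminal hydrolase 7 (Homo sapiens), read by spectrophotometry, with stated times of 30 min and 2 h (a higher number here means a weaker inhibitor, a lower number a stronger inhibitor), compound 1 gives 157 nM. Compound 3 `COC(=O)c1ccc(CN2CCC(O)(Cn3cnc4c(cnn4-c4ccc(F)cc4)c3=O)CC2)c(F)c1` shares its core with compound 2 and compound 4 but carries a different benzyl group on the ring amine; in this assay compound 3 gives 800 nM. Compound 2 `O=c1c2cnn(-c3ccc(F)cc3)c2ncn1CC1(O)CCN(Cc2ccc(C(F)(F)F)cc2)CC1` has in this assay only the entry "not determined" (no result reported), so it stands on no number at all, and its place among the others cannot be read off.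

Compound 4 `N#Cc1cc(Cl)ccc1CN1CCC(O)(Cn2cnc3c(cnn3-c3ccc(F)cc3)c2=O)CC1` has not yet been measured in this assay. It differs from compound 2 in one place: 4-chloro-2-cyanophenyl in place of 4-(trifluoromethyl)phenyl on a saturated chain carbon bound to an amine nitrogen in a ring. For the measured compounds named here, no measured pair here shows the size of such a change, and with compound 2 unmeasured, nothing direct can be said of its direction. The closest anchor is compound 3, whose value 800 nM sits on the same core with a related benzyl group. The value for compound 4 in this assay is therefore expected near 500 nM, most likely between 150 nM and 2000 nM.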

Compound 4, half-maximal inhibitory concentration: 11400 nM
The estimate for compound 4 lay 23-fold (1.36 log units) below the measured number; measured number outside the range, above it.
By their numbers in this assay, from the lowest: compound 1; then compound 3; then compound 4.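

On the shared core, the group on the saturated chain carbon bound to the amine nitrogen in the ring strongly affects the result in this assay: placing 4-chloro-2-cyanophenyl there instead of 2-fluoro-4-(methoxycarbonyl)phenyl gives a 14-fold higher number from compound 3 to compound 4 (1.15 log units; beyond the scatter). For the compounds shown here, until now, only one compound on this core had a number, so the size of a change at this position could not be seen; this step lies well beyond the usual scatter. Nothing measured here explains the weaker result.

Compound 2 has no number, so its step to compound 4 cannot be read, and the swap in the step above changes several ring substituents at once, leaving open which of them matters. As far as these compounds go, whether a carboxylic acid or an amine on this ring would give a stronger or weaker inhibitor also remains open.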